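Same atoms, joined differently: an estimate for compound 4

The compounds below may be only part of what the source reports. "The series", "measured", "known", "first", "only" and "open" are said of these compounds alone.

Compound 1 `N/C(=N\O)c1ccc(S(=O)(=O)C2=C(c3ccc(Nc4cccc(/C(N)=N/O)c4)cc3)OC(c3ccccc3)(c3ccccc3)C2)cc1` gives 48100 nM in an ADME assay on THP-1 cells (Homo sapiens) for cytotoxicity, read by flow cytometry, with a stated time of 72 h; a lower number here means a stronger inhibitor, a higher number a weaker inhibitor.
Compound 2 `CC1(Cc2ccccc2)CC(S(=O)(=O)c2ccc(/C(N)=N/O)cc2)=C(c2ccc(Nc3cccc(/C(N)=N/O)c3)cc2)O1` gives 44000 nM in this assay.
Compound 3 `N/C(=N\O)c1ccc(S(=O)(=O)C2=C(c3ccc(Nc4ccccc4/C(N)=N/O)cc3)OC(c3ccccc3)(c3ccccc3)C2)cc1` gives 47800 nM in this assay.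

Compound 1 and compound 3 differ by a group of 10 heavy atoms (7 carbon, 2 nitrogen, 1 oxygen; one six-membered aromatic ring of carbon only) in place of a group of 10 heavy atoms (7 carbon, 2 nitrogen, 1 oxygen; one six-membered aromatic ring of carbon only), on a nitrogen on an aromatic ring, and this change gave a 1.0-fold lower number from compound 1 to compound 3 (0.00 log units; within the scatter). Compound 2 shares the same kind of group on the aromatic nitrogen as compound 1, but its core differs from that of compound 1, and that difference between the two cores is not broken down here; the values of compound 1 and compound 2 lie within the scatter of each other. Compound 4 `CC1(Cc2ccccc2)CC(S(=O)(=O)c2ccc(/C(N)=N/O)cc2)=C(c2ccc(Nc3ccccc3/C(N)=N/O)cc2)O1` differs from compound 2 by a group of 10 heavy atoms (7 carbon, 2 nitrogen, 1 oxygen; one six-membered aromatic ring of carbon only) in place of a group of 10 heavy atoms (7 carbon, 2 nitrogen, 1 oxygen; one six-membered aromatic ring of carbon only), on a nitrogen on an aromatic ring, the same change as from compound 1 to compound 3. Because a 1.0-fold lower number from compound 1 to compound 3 (0.00 log units; within the scatter) lay within the scatter, the step from compound 2 to compound 4 is expected to be no change at the digits printed from compound 2 to compound 4 (within the scatter). Compound 4 is therefore estimated at 44000 nM, expected to fall between 25000 nM and 80000 nM.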

Compound 4, half-maximal inhibitory concentration: 48100 nM
Estimate against measurement, compound 4: 1.1-fold (0.04 log units) below; low and high end bracket the measured number.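

In this assay the change on the aromatic nitrogen gave a 1.1-fold higher number from compound 2 to compound 4 (0.04 log units; within the scatter), and it behaved alike on the two cores: the same change on two cores in this assay, a 1.0-fold lower number (0.00 log units; within the scatter) from compound 1 to compound 3 and a 1.1-fold higher number (0.04 log units; within the scatter) from compound 2 to compound 4, 1.1-fold (0.04 log units) apart, within the scatter of two such steps Across these four compounds, then, the change carried from the core of compound 1 to the core of compound 2 as a step within the scatter on both. Neither core showed a step beyond the scatter, so the pair does not show that a step of real size would carry over, and it speaks for these two cores only.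

Still open, going by these compounds, is whether a carboxylic acid or a nitrile in place of the group that changed would move the number in this assay. Also open, on these data alone, is whether the same change would stay as small on a third core, such as one carrying an amine.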